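Swapping fluoro for methoxy on a methylthio imidazole

The source may report more compounds than this note shows. Statements on the series, on what has been measured and on what is new or still open speak of the compounds shown alone.

This series shares one core and varies two outer groups. Compound 1 `CSc1ncc(-c2ccc(S(C)(=O)=O)cc2)n1-c1ccc(F)cc1` gives 40% in a functional assay on the whole organism (strain Sprague-Dawley) with Rattus norvegicus as the target, read by paw edema, with a stated time of 3 h, at a dose of 50 mg/kg by the oral route; a higher number here means more inhibition at the dose given (going by the name of the read-out), a lower number less inhibition. That is the lowest of the three numbers measured; the nearest, compound 2 `CCSc1ncc(-c2ccc(S(C)(=O)=O)cc2)n1-c1ccc(F)cc1`, gives 65%, and the furthest, compound 3 `CCSc1ncc(-c2ccc(S(C)(=O)=O)cc2)n1-c1ccc(Br)cc1`, gives 66%.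

Two single changes have been measured. The step of a number 25 percentage points higher from compound 1 to compound 2 (beyond the scatter) is beyond the scatter. The step of a number 1 percentage points higher from compound 2 to compound 3 (within the scatter) stays within the scatter, and that step changes the same aromatic carbon that is changed on the way to compound 4.

Compound 4 `COc1ccc(-n2c(-c3ccc(S(C)(=O)=O)cc3)cnc2SC)cc1` differs from compound 1 in one place: methoxy in place of fluoro on an aromatic carbon. Within the data shown here, the only measured change at that carbon, one halogen for another, did nothing beyond the scatter, but no measured step replaces a halogen with methoxy, so the expectation rests on thin ground. Compound 4 is therefore expected to sit near compound 1, with an estimated step of a number 2 percentage points higher from compound 1 to compound 4 (within the scatter). The estimate for compound 4 is 42%, in a range from 22% to 62%.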

Compound 4, a percentage reported as inhibition, in the whole organism at one dose (the size of the read-out at that dose, not a potency): 41.3%
Compound 4: middle estimate off by 0.7 percentage points, on the high side; low and high end bracket the measured number.
By their numbers in this assay, from the lowest: compounds 1 and 4 (each within the scatter of the next); then compounds 2 and 3 (each within the scatter of the next).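

Replacing 4-fluorophenyl with 4-methoxyphenyl gives a number 1.3 percentage points higher from compound 1 to compound 4 (within the scatter) in this assay, so this aromatic carbon can carry a group that is not a halogen, with two heavy atoms in place of one and a hydrogen-bond acceptor, without a difference this read-out can separate. Both measured changes at this carbon now stay within the scatter, on either chain at the sulfur, whereas the step at the sulfur chain itself, a number 25 percentage points higher from compound 1 to compound 2 (beyond the scatter) is beyond it. Nothing measured here bears on why this result came out as it did.

As far as these compounds go, whether an amine, a carboxylic acid or a longer chain such as ethoxy at this carbon would also leave the number unmoved remains open. So does whether methoxy behaves the same alongside the ethyl group on the sulfur of compound 2.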